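This account rests on a few compounds, and the source may have more. Where it says the series, first, only, none or still open, it means among the compounds named here.

The study follows growth inhibition in a functional assay on A-375 cells (Homo sapiens) for antiproliferative activity; a higher number here means a weaker inhibitor, a lower number a stronger inhibitor. Compound 1 `Cc1cc2c(F)c(Oc3ncnc(N)c3/C=N/OCCO)ccc2[nH]1` gives 372 nM in this assay. Compound 2 `CO/N=C/c1c(N)ncnc1Oc1cc2cc[nH]c2cc1F` gives 327 nM in this assay. Within the data shown here, these two numbers lie within the scatter of each other, so compound 1 cannot be set apart from compound 2 on what has been measured, and no step between measured compounds has been worked out. Compound 3 `COCCCO/N=C/c1c(N)ncnc1Oc1ccc2[nH]c(C)cc2c1F` is not yet measured. It differs from compound 1 in one place: methoxymethyl in place of hydroxy on a saturated chain carbon, two bonds along the chain from an oxygen. Nothing measured here speaks to such a change, so any expectation rests only on compounds 1 and 2, whose near-equal numbers point in no direction. The shift is therefore expected to be small and without a clear direction beyond the scatter, and a 1.2-fold lower number from compound 1 to compound 3 (0.07 log units; within the scatter) is the estimated step. Compound 3 is expected to give 320 nM in this assay, within a range from 120 nM to 850 nM.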

Compound 3, half-maximal inhibitory concentration: 300 nM
Beside the measured number, compound 3's estimate is 1.1-fold (0.03 log units) above it; the range from low to high includes it.
By their numbers in this assay, from the lowest: compounds 3, 2 and 1 (each within the scatter of the next).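

In this assay, among these compounds, replacing 2-hydroxyethoxy with 3-methoxypropoxy gives a 1.2-fold lower number from compound 1 to compound 3 (0.09 log units; within the scatter), the first step between measured compounds that differ in one place. At this position, then, the hydroxy group with its hydrogen-bond donor can give way to methoxymethyl, which has none, with no shift that can be told apart from the scatter. Nothing else measured here offers an explanation for this result.

The step changes the chain end and the chain length together, so 3-hydroxypropoxy or 2-methoxyethoxy would be needed to show whether either change alone leaves the number as flat. As far as these compounds go, whether an amine, a carboxylic acid or a much longer chain at this position would move the number beyond the scatter also remains open.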